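This account rests on a few compounds, and the source may have more. Where it says the series, first, only, none or still open, it means among the compounds named here.

In a functional assay on the whole organism (arterial blood) with Rattus norvegicus as the target (on this read-out higher numbers stand for an effect only at larger amounts of compound and lower numbers for an effect already at smaller amounts), compound 1 `Cc1nc2cnccc2n1CC1CCN(C(=O)CC(C)c2ccccc2)CC1` gives 0.033 mg/kg, within the usual scatter of both compound 2 `CCOC(=O)[C@@H](NC(=O)N1CCC(Cn2c(C)nc3cnccc32)CC1)c1ccccc1` at 0.061 mg/kg and compound 3 `CCOC[C@@H](NC(=O)N1CCC(Cn2c(C)nc3cnccc32)CC1)c1ccccc1` at 0.019 mg/kg. Compound 4 `Cc1nc2cnccc2n1CC1CCN(C(=O)CN(C)c2ccccc2)CC1` differs from compound 1 as follows: methyl(phenyl)amino in place of 1-phenylethyl on a saturated chain carbon bound to a carbonyl carbon. In words, this is methyl(phenyl)amino in place of 1-phenylethyl on a saturated chain carbon bound to a carbonyl carbon. For the measured compounds named here, the only measured step, a 3.2-fold lower number from compound 2 to compound 3 (0.51 log units; beyond the scatter), is modest and concerns a different exchange, ethoxymethyl in place of ethoxycarbonyl, so it bears only indirectly. Going by the values given here, no measured step covers the present exchange. The estimated step, a 1.2-fold higher number from compound 1 to compound 4 (0.08 log units; within the scatter), is expected to stay within the scatter, with no direction expected in this assay. For compound 4 the estimate is 0.04 mg/kg, with an expected range of 0.012 mg/kg to 0.13 mg/kg.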

Compound 4, dose for 50% inhibition: 0.31 mg/kg
The estimate for compound 4 lay 7.8-fold (0.89 log units) below the measured number; the measured number lies above the stated range.
By their numbers in this assay, from the lowest: compounds 3, 1 and 2 (each within the scatter of the next, the first and the last beyond it); then compound 4.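

In this assay, the exchange of 1-phenylethyl for methyl(phenyl)amino on a saturated chain carbon bound to a carbonyl carbon gives a 9.4-fold higher number from compound 1 to compound 4 (0.97 log units; beyond the scatter). Both groups have 8 heavy atoms and the same aromatic ring, so this position is not indifferent to an exchange that keeps those counts; the entering group differs by a nitrogen and one hydrogen-bond acceptor. Open, going by these compounds, is whether a phenoxy group or an unmethylated phenylamino group at this place would follow compound 1 or compound 4. No measurement shown here explains the step.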